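Methoxymethyl to methyl: working notes on compound 3

A few compounds are considered here, and "the series" means these few. Any claim that something is new, unique, unknown or untested is made for them only; others in the source may bear on it.

Measured so far in a functional assay on MES-SA cells (Homo sapiens) for cytotoxicity, read by luminescence and CellTiter-Glo, with a stated time of 72 h (a lower number here means a stronger inhibitor, a higher number a weaker inhibitor), are two compounds
- compound 1 `COC[C@H](NC(=O)c1cc(C)on1)C(=O)N[C@@H](CC#N)C(=O)N[C@@H](CC(C)C)C(=O)[C@@]1(C)CO1` with 29 nM
- compound 2 `COC[C@H](NC(=O)c1cc(C)on1)C(=O)N[C@@H](COC)C(=O)N[C@@H](CC(C)C)C(=O)[C@@]1(C)CO1` with 22 nM

Compound 2 and compound 1 lie within the usual scatter of each other, so neither ranks ahead. Compound 3 `COC[C@H](NC(=O)c1cc(C)on1)C(=O)N[C@@H](C)C(=O)N[C@@H](CC(C)C)C(=O)[C@@]1(C)CO1` differs from compound 2 in one place: hydrogen in place of methoxy on a saturated chain carbon, two bonds along the chain from an amide-type nitrogen and a carbonyl carbon with hydrogen in place of methoxy on a saturated chain carbon, two bonds along the chain from an amide-type nitrogen and a carbonyl carbon. Going by the values given here, the one measured step at this carbon is a 1.3-fold lower number from compound 1 to compound 2 (0.12 log units; within the scatter) and stays within the scatter, with cyano and methoxy exchanged. Among the compounds with values here, no measured compound yet carries the plain methyl, so this precedent is indirect. In this assay the expected step is a 1.4-fold higher number from compound 2 to compound 3 (0.13 log units; within the scatter) and no change beyond the scatter is expected. The estimate for compound 3 is 30 nM with 12 nM to 80 nM as its expected range.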

Compound 3, half-maximal inhibitory concentration in the MES-SA assay: 28 nM
Beside the measured number, compound 3's estimate is 1.1-fold (0.03 log units) above it, and the stated range covers the measured number.
By their numbers in the MES-SA assay, from the lowest: compounds 2, 3 and 1 (each within the scatter of the next).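

In the MES-SA assay, the steps at this carbon stay within the scatter: a 1.3-fold higher number from compound 2 to compound 3 (0.10 log units; within the scatter) and a 1.0-fold lower number from compound 1 to compound 3 (0.02 log units; within the scatter). The plain methyl, the methoxymethyl and the cyano-bearing chain are therefore not told apart in this read-out, and the small methyl gives up nothing measurable here. In a physicochemical assay for metabolic stability, in simulated intestinal fluid, with a stated time of 15 min, tested at 4 uM (a higher number here means that more of the compound is left, a lower number that less of the compound is left), compound 2 gives 70% and compound 3 gives 100%. The same change does separate compound 2 and compound 3 in the physicochemical assay, the only step here beyond the scatter, so this position matters in the physicochemical assay even where the cell numbers stay level: the measured percent of the compound remaining of compound 2, 70%, and of compound 3, 100%, a number 30 percentage points higher (beyond the scatter)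

Still open, going by these compounds, is whether a longer chain or an amine at this carbon would hold the cell number in the MES-SA assay and the result in the physicochemical assay. A single pair also cannot say whether the oxygen itself or the length of the chain accounts for the gap in the physicochemical assay.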